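This account rests on a few compounds, and the source may have more. Where it says the series, first, only, none or still open, it means among the compounds named here.

Among the compounds with values here, compound 1 `CC(=O)Nc1ccc(S(=O)(=O)NNC(=O)c2cccnc2Nc2ccc(Cl)cc2)cc1` is a sulfonohydrazide built on a shared core; in a functional assay on ACHN cells (Homo sapiens) for antiproliferative activity (a lower number here means a stronger inhibitor of growth, a higher number a weaker inhibitor of growth), compound 1 gives 75900 nM, the only numerical value. Compound 2 `O=C(NNS(=O)(=O)c1ccc(F)cc1)c1cccnc1Nc1ccc(Cl)cc1Cl` reaches only a limit of the assay in this assay, > 100000 nM, at the ceiling described by the limit of > 100000 nM in this assay, at which 1 of the 2 values shown sits. Compound 3 `O=C(NNS(=O)(=O)c1ccc(Cl)cc1Cl)c1cccnc1Nc1ccc(Cl)cc1` arises from compound 1 by 2,4-dichlorophenyl in place of 4-acetamidophenyl on a sulfonyl sulfur. Within the data shown here, no measured step covers this change, so the expected shift from compound 1 to compound 3, a 1.3-fold lower number from compound 1 to compound 3 (0.10 log units; within the scatter), is estimated as small and within the usual scatter, with a real chance of another limit. Compound 3 is therefore expected to give about 60000 nM, between 20000 nM and 150000 nM.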

Compound 3, concentration for total growth inhibition: 93300 nM
Compound 3: middle estimate off by 1.6-fold (0.19 log units), on the low side; the range from low to high includes it.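

In this assay, within the data shown here, 2,4-dichlorophenyl in place of 4-acetamidophenyl on a sulfonyl sulfur gives a 1.2-fold higher number from compound 1 to compound 3 (0.09 log units; within the scatter) as the first measured step at this position. Losing the acetamido group and adding two chlorines therefore leaves the number essentially unmoved. Compound 2 gives only a limit of the assay: the limit of > 100000 nM in this assay, at which 1 of the 3 values shown sits.

Going by these compounds, whether an amine or a carboxylic acid on this phenyl ring would move the number beyond the scatter remains open. So does the effect of a longer alkyl chain in place of the ring.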